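Pyrazole nitrogen substituent in a kinase inhibitor series

A few compounds are considered here, and "the series" means these few. Any claim that something is new, unique, unknown or untested is made for them only; others in the source may bear on it.

Measured so far in an assay on HEK293 cells for inhibition of Leucine-rich repeat serine/threonine-protein kinase 2 variant G2019S (Homo sapiens), with a stated time of 48 h; a lower number here means a stronger inhibitor, a higher number a weaker inhibitor:
compound 1, `Cc1nn(C2COC2)cc1Nc1nc(N)c2c(C#N)c(N3CCC[C@H]3C)n(C)c2n1`: 140 nM
compound 2, `Cc1c(Nc2nc(N)c3c(C#N)c(N4CCC[C@H]4C)n(C)c3n2)cnn1[C@H]1CCOC1`: 51 nM

Of the two numbers, compound 1 has the higher one; compound 2 gives a lower number, and the gap between them lies beyond the usual scatter. Compound 3, `Cc1nn(C)cc1Nc1nc(N)c2c(C#N)c(N3CCC[C@H]3C)n(C)c2n1`, is not yet measured. It differs from compound 1 only in one place: methyl in place of oxetan-3-yl on an aromatic nitrogen. For the measured compounds named here, no pair of measured compounds shows this same change, so the size of the step is open. The smaller group is expected to give a somewhat higher number, within a modest step, a 1.6-fold higher number from compound 1 to compound 3 (0.20 log units; within the scatter). For compound 3 the expected value in this assay is 220 nM, with a plausible range of 70 nM to 650 nM.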

Compound 3, half-maximal inhibitory concentration: 120 nM
Beside the measured number, compound 3's estimate is 1.8-fold (0.26 log units) above it; the measured number falls inside the stated range.
By their numbers in this assay, from the lowest: compound 2; then compounds 3 and 1 (each within the scatter of the next).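

In this assay, methyl in place of oxetan-3-yl on the aromatic nitrogen gives a 1.2-fold lower number from compound 1 to compound 3 (0.07 log units; within the scatter). At this position, then, the four-membered ring and its oxygen can be exchanged for methyl with no step beyond the scatter, which compounds 1 and 2 alone could not show. No measurement at hand accounts for this result.

From the compounds shown here alone, whether an amine or a longer chain such as n-butyl on this nitrogen would move the number remains open. Compound 2 differs from compound 3 in more than one place, so its value cannot be tied to a single change.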